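A Tetrazole Takes the Place of the Sulfone

The source may report more compounds than this note shows. Statements on the series, on what has been measured and on what is new or still open speak of the compounds shown alone.

Two compounds share one core and differ in a single group on a saturated chain carbon, three bonds along the chain from an oxygen on an aromatic ring. Compound 1, `CCc1cc(C(C)=O)c(O)cc1OCCCC(C)(C)C(N)=O`, carries 1-carbamoyl-1-methylethyl there, and in an assay on isolated protein for binding affinity to leukotriene B4 receptor 1 (Homo sapiens), tested at 1 uM (a higher number here means more inhibition at the concentration tested (going by the name of the read-out), a lower number less inhibition), compound 1 gives 51%. Compound 2, `CCc1cc(C(C)=O)c(O)cc1OCCCCCCS(C)(=O)=O`, carries 3-(methylsulfonyl)propyl instead, and in this assay compound 2 gives 62%. Compound 2 thus stands highest of the two numbers shown, with compound 1 as its only neighbour, lower by a margin beyond the scatter.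

Compound 3, `CCc1cc(C(C)=O)c(O)cc1OCCCCc1nnn[nH]1`, is reached from compound 2 by one change: 1H-tetrazol-5-yl in place of 2-(methylsulfonyl)ethyl on a saturated chain carbon, four bonds along the chain from an oxygen on an aromatic ring. Within the data shown here, the only measured step that bears on this is a number 11 percentage points higher from compound 1 to compound 2 (beyond the scatter), which also exchanged the group at that part of the chain and moved the number modestly. A further exchange there could plausibly shift the number by a similar amount in either direction, so no step beyond the scatter is expected with confidence. For compound 3 the expected step is a number 10 percentage points lower from compound 2 to compound 3 (within the scatter). Compound 3 is therefore estimated at 52%, within a range from 32% to 72%.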

Compound 3, a percentage reported as inhibition, at one concentration (the size of the read-out at that concentration, not a potency): 19%
For compound 3 the middle estimate is 33 percentage points above the measured one; measured number below the stated range.
By their numbers in this assay, from the lowest: compound 3; then compound 1; then compound 2.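

At this position the group is not freely exchangeable: in this assay, 1H-tetrazol-5-yl in place of 2-(methylsulfonyl)ethyl gives a number 43 percentage points lower from compound 2 to compound 3 (beyond the scatter), a large step where the earlier exchange of groups gave only a modest one. Compared with the amide, (1H-tetrazol-5-yl)methyl in place of 1-carbamoyl-1-methylethyl gives a number 32 percentage points lower from compound 1 to compound 3 (beyond the scatter), so the sulfone and the amide both stand clearly above the tetrazole, although the change also shortens the chain, leaving the ring and the chain length entangled in a single step. Nothing shown here explains the drop.

The compounds shown leave open whether the tetrazole itself or the shorter chain accounts for the loss, and a tetrazole on a longer chain, ending where the sulfone of compound 2 ends, would separate the two. They also leave open how a carboxylic acid or an amine at the end of the same chain would compare with these three groups.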